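Adding a second methoxy to compound 3

The compounds below may be only part of what the source reports. "The series", "measured", "known", "first", "only" and "open" are said of these compounds alone.

Measured in a functional assay on DU-145 cells (Homo sapiens) for inhibition, read by MTT assay, with a stated time of 72 h; on this read-out higher numbers stand for weaker inhibition and lower numbers for stronger inhibition:
compound 1 `COc1ccc(N2CCN(C3=CC(=O)c4ccccc4C3=O)CC2)cc1` gives 46100 nM
compound 2 `Cc1ccccc1N1CCN(C2=CC(=O)c3ccccc3C2=O)CC1` gives 5700 nM
compound 3 `COc1cccc(N2CCN(C3=CC(=O)c4ccccc4C3=O)CC2)c1` gives 15000 nM

Compound 3 holds the middle of the three numbers, with a 2.6-fold higher number from compound 2 to compound 3 (0.42 log units; beyond the scatter) and a 3.1-fold lower number from compound 1 to compound 3 (0.49 log units; beyond the scatter) as the steps that place it there. Compound 4 `COc1ccc(N2CCN(C3=CC(=O)c4ccccc4C3=O)CC2)cc1OC` is not yet measured. It follows from compound 3 by methoxy in place of hydrogen on an aromatic carbon, ortho to a methoxy group and para to a large group: methoxy in place of hydrogen on an aromatic carbon.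

Within the data shown here, no measured step adds a second group to the ring, so the evidence is indirect. Compound 4 gains the methoxy that compound 1 carries para to a large group, and compound 1 has the highest number. The nearest guide is a 3.1-fold lower number from compound 1 to compound 3 (0.49 log units; beyond the scatter), a modest step, read here in reverse, with an 8.1-fold lower number from compound 1 to compound 2 (0.91 log units; beyond the scatter) pointing the same way. A modest move toward a higher number, meaning weaker inhibition, is therefore expected in this assay. The expected step is a 2.1-fold higher number from compound 3 to compound 4 (0.33 log units; beyond the scatter) in this estimate. For compound 4 the estimated value is 32000 nM, with an expected range from 11000 nM to 80000 nM.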

Compound 4, half-maximal inhibitory concentration: 17800 nM
The estimate for compound 4 lay 1.8-fold (0.25 log units) above the measured number, and the stated range covers the measured number.
By their numbers in this assay, from the lowest: compound 2; then compounds 3 and 4 (each within the scatter of the next); then compound 1.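

In this assay, compound 3 and compound 4 cannot be told apart (a 1.2-fold higher number from compound 3 to compound 4 (0.07 log units; within the scatter)), so methoxy in place of hydrogen on this aromatic carbon, ortho to a methoxy group and para to a large group, is tolerated when the other methoxy is present. Compound 4 still separates from the single-methoxy compound 1 (a 2.6-fold lower number from compound 1 to compound 4 (0.41 log units; beyond the scatter)), so a methoxy para to a large group does not by itself set the high number of compound 1. Nothing available here explains this outcome.

Going by these compounds, it remains open whether a hydroxy group, an amine or a longer alkoxy chain at this carbon would fit the same pattern. Also open, on these data alone, is whether a second group elsewhere on this ring, such as chlorine, would behave like this methoxy.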